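A few compounds are considered here, and "the series" means these few. Any claim that something is new, unique, unknown or untested is made for them only; others in the source may bear on it.

Measured compounds in an assay on H9c2 cells for inhibition of tumor necrosis factor receptor superfamily member 6 (Rattus norvegicus), with stated times of 30 min and 6 h; a higher number here means that more compound is needed for the effect, a lower number that less compound is needed:
compound 1 `COC(=O)c1oc2ccccc2c1NC(=O)CSc1ccc([N+](=O)[O-])cc1` gives 575 nM
compound 2 `COC(=O)c1oc2ccccc2c1NC(=O)COc1ccc(Br)cc1` gives 1050 nM
compound 3 `COC(=O)c1oc2cccc(Cl)c2c1NC(=O)CSc1ccccn1` gives 646 nM

Compound 3 stands second highest of the three numbers. Its nearest neighbour is compound 1, whose number is a little lower, and its furthest is compound 2, whose number is higher; both gaps lie within the usual scatter of repeated measurements, so the three compounds cannot be ordered against each other on these numbers.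

Compound 4 `COC(=O)c1oc2cccc(Cl)c2c1NC(=O)CCSc1ccccn1` has not yet been measured in this assay. It differs from compound 3 in one place: ((pyridin-2-yl)sulfanyl)methyl in place of (pyridin-2-yl)sulfanyl on a saturated chain carbon bound to a carbonyl carbon. The acetamide linker of compound 3 is thereby lengthened by one saturated carbon, with the same aromatic ring and the same count of donors and acceptors retained.

Among the compounds with values here, no measured pair in this set shows such a chain lengthening, so there is no directly comparable step to lean on. The expectation is that the change moves the number only modestly, if at all, most likely by a small step towards a higher value that stays within the scatter, so a 1.2-fold higher number from compound 3 to compound 4 (0.09 log units; within the scatter) is estimated for the step from compound 3 to compound 4. For compound 4 the estimate is 800 nM, with a range from 350 nM to 2000 nM.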

Compound 4, half-maximal effective concentration: 631 nM
Compound 4: middle estimate off by 1.3-fold (0.10 log units), on the high side; the measured number falls inside the stated range.
By their numbers in this assay, from the lowest: compounds 1, 4, 3 and 2 (each within the scatter of the next).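

In this assay, within the data shown here, ((pyridin-2-yl)sulfanyl)methyl in place of (pyridin-2-yl)sulfanyl on a saturated chain carbon bound to a carbonyl carbon gives a 1.0-fold lower number from compound 3 to compound 4 (0.01 log units; within the scatter), the first comparison in this set of compounds that differ in one place. In this single pair, the added saturated carbon leaves the number within the scatter, so the two chain lengths cannot be told apart at this place. Nothing measured here accounts for this result.

The compounds shown leave open whether a longer chain, or an amine or a carboxylic acid in place of the (pyridin-2-yl)sulfanyl group, would keep the number at this level. They also leave open whether the same added carbon would read alike on the core of compound 1.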